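Replacing the 6-methoxypyridin-3-yl group of compound 3

The source may hold more compounds than are shown below. What is called first, only, known or untested is meant among the compounds shown, and "the series" means these compounds.

In a functional assay on HeLa cells (Homo sapiens) for antiproliferative activity, read by MTT assay, with a stated time of 48 h (on this read-out lower numbers stand for stronger inhibition and higher numbers for weaker inhibition), compound 1 `COc1ccc(-c2nc3cnccc3n2-c2cc(OC)c(OC)c(OC)c2)cc1O` gives > 20000 nM, which is a limit of the assay and not a number. Compound 2 `COc1ccc(-c2cc3c(cn2)[nH]c(=O)n3-c2cc(OC)c(OC)c(OC)c2)cc1O` gives 490 nM, and compound 3 `COc1ccc(-c2cc3c(cn2)[nH]c(=O)n3-c2cc(OC)c(OC)c(OC)c2)cn1` gives 870 nM. Compound 3 and compound 2 therefore stand within the scatter of each other. Compound 4 `COc1ccc(-c2cc3c(cn2)[nH]c(=O)n3-c2cc(OC)c(OC)c(OC)c2)cc1N` carries 3-amino-4-methoxyphenyl in place of the 6-methoxypyridin-3-yl of compound 3 (3-amino-4-methoxyphenyl in place of 6-methoxypyridin-3-yl on an aromatic carbon). For the measured compounds named here, the only measured step at this place, a 1.8-fold higher number from compound 2 to compound 3 (0.25 log units; within the scatter), stayed within the scatter. In this assay, no step beyond the scatter is therefore expected, and any shift should lean towards a lower number. The expected change is a 1.7-fold lower number from compound 3 to compound 4 (0.24 log units; within the scatter). For compound 4 the estimated value is 500 nM, with an expected range from 120 nM to 1800 nM.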

Compound 4, half-maximal inhibitory concentration: 770 nM
Compound 4: middle estimate off by 1.5-fold (0.19 log units), on the low side; low and high end bracket the measured number.
By their numbers in this assay, from the lowest: compounds 2, 4 and 3 (each within the scatter of the next). At a limit, above all of these: compound 1.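

In this assay the change brought a 1.1-fold lower number from compound 3 to compound 4 (0.05 log units; within the scatter) and so a ring of carbon only carrying amino and methoxy can stand at this place in lieu of 6-methoxypyridin-3-yl with no shift beyond the scatter. Amino in place of hydroxy brought a 1.6-fold higher number from compound 2 to compound 4 (0.20 log units; within the scatter) and this leaves compound 2, compound 3 and compound 4 all within the scatter of one another. Nothing measured here speaks to why these changes leave the number where it is.

Going by these compounds, whether a carboxylic acid, a dimethylamino group or a longer alkoxy chain on this ring would move the number beyond the scatter stays open.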